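Removing the Phenyl Group from a Fused Core

The source may report more compounds than this note shows. Statements on the series, on what has been measured and on what is new or still open speak of the compounds shown alone.

Measured compounds:
compound 1, `Cc1cc(NCc2nccn2C)n2nc(C)c(-c3ccccc3)c2n1`, 26900 nM
compound 2, `Cc1cc(NCc2cccs2)n2nc(C)c(-c3ccccc3)c2n1`, < 5000 nM

In a physicochemical assay for solubility, read by HPLC, using the shake flask method, measured as kinetic solubility, with a stated time of 2 h, at pH 7.4 (a higher number here means a more soluble compound, a lower number a less soluble compound), compound 1 gives 26900 nM. For compound 2 this assay reports only a limit, < 5000 nM. Within the data shown here, compound 1 therefore stands as the only compound with a number; the other value is a limit. Among the measured compounds shown here, the one measured step runs an at least 5.3-fold lower number from compound 1 to compound 2 (0.73 log units; beyond the scatter), and its size is bounded by the limit of < 5000 nM in this assay, at which 1 of the 2 values shown sits.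

Compound 3, `Cc1cc(NCc2nccn2C)n2nc(C)cc2n1`, keeps the chain and the methylated imidazolyl group of compound 1 and differs from it only in one place: hydrogen in place of phenyl on an aromatic carbon. The measured step from compound 1 to compound 2 concerns the group on the saturated chain carbon, not the aromatic carbon of the fused core, so it gives no direct guide for this change. The two compounds share the whole remainder of the structure, so compound 1 is the reference for compound 3. Compound 3 is estimated to give 70000 nM in this assay, with a range from 25000 nM to 200000 nM, which would be an expected step of a 2.6-fold higher number from compound 1 to compound 3 (0.42 log units; beyond the scatter).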

Compound 3, solubility: 182000 nM
The estimate for compound 3 lay 2.6-fold (0.41 log units) below the measured number; the range from low to high includes it.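

Compound 3 shows that the aromatic carbon of the five-membered aromatic ring is a place where the number in this assay moves: hydrogen in place of phenyl gives a 6.8-fold higher number from compound 1 to compound 3 (0.83 log units; beyond the scatter). Among these compounds, the only earlier step concerned the group on the saturated chain carbon and ended at a limit, whereas this one concerns the fused core and runs between two actual numbers, so its size can be read directly. Nothing measured here accounts for the size or direction of this step, and the phenyl group's contribution to the number rests on this single pair.

The compounds shown leave open whether a smaller substituent at this aromatic carbon, such as a methyl group or a chlorine atom, or a different ring such as pyridin-3-yl, would give a number nearer that of compound 1 or that of compound 3. They also leave open whether hydrogen in place of phenyl would raise the number to a similar extent when thiophen-2-yl, as in compound 2, stands on the saturated chain carbon.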